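Swapping the Chain Back for a Ring on the Shared Core

This account rests on a few compounds, and the source may have more. Where it says the series, first, only, none or still open, it means among the compounds named here.

Among the three measured compounds, compound 3 `COc1ccc(CN2CCc3nc(-c4ccccn4)nc(NCCCn4ccnc4)c3C2)cc1` gives the lowest number: in an assay on FRT cells with Cystic fibrosis transmembrane conductance regulator variant F508del (Homo sapiens) as the target, read by fluorescence, with a stated time of 25 min (on this read-out higher numbers stand for an effect only at larger amounts of compound and lower numbers for an effect already at smaller amounts), compound 3 gives 200 nM. Compound 2 `COc1ccc(CN2CCc3nc(-c4ccccn4)nc(N4CCC(C(N)=O)CC4)c3C2)cc1` gives 3500 nM, and compound 1 `NC(=O)CN1CCN(c2nc(-c3ccccn3)nc3c2CN(Cc2ccccc2)CC3)CC1` gives 2800 nM. Compound 4 `COc1ccc(CN2CCc3nc(-c4ccccn4)nc(N4CCN(CC(N)=O)CC4)c3C2)cc1` differs from compound 3 by 4-(carbamoylmethyl)piperazin-1-yl in place of (3-(1H-imidazol-1-yl)propyl)amino on an aromatic carbon. Among the compounds with values here, the only measured step that bears on this is an 18-fold lower number from compound 2 to compound 3 (1.24 log units; beyond the scatter), in which a cyclic carbamoyl amine gave way to the imidazolylpropylamino chain; compound 4 reverses that kind of change. Compound 1 already carries the entering group and sits near compound 2 in this assay. Compound 4 is therefore expected to show a 13-fold higher number from compound 3 to compound 4 (1.10 log units; beyond the scatter), moving back toward those numbers. The estimate for compound 4 is 2500 nM, within a range of 1000 nM to 6000 nM.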

Compound 4, half-maximal effective concentration in the Cystic fibrosis transmembrane conductance regulator assay: 2300 nM
The estimate for compound 4 lay 1.1-fold (0.04 log units) above the measured number; the range from low to high includes it.
By their numbers in the Cystic fibrosis transmembrane conductance regulator assay, from the lowest: compound 3; then compounds 4, 1 and 2 (each within the scatter of the next).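

In the Cystic fibrosis transmembrane conductance regulator assay the step of a 12-fold higher number from compound 3 to compound 4 (1.06 log units; beyond the scatter) shows that, on this aromatic carbon, 4-(carbamoylmethyl)piperazin-1-yl does not keep the low number of compound 3, 200 nM, seen with (3-(1H-imidazol-1-yl)propyl)amino, whereas a 1.5-fold lower number from compound 2 to compound 4 (0.18 log units; within the scatter) and a 1.2-fold lower number from compound 1 to compound 4 (0.09 log units; within the scatter) leave compound 4, at 2300 nM, level with the two other compounds that carry a carbamoyl ring. In a physicochemical assay for solubility, read by HPLC, with a stated time of 24 h, at pH 7.4, tested at 250 uM (a lower number here means a less soluble compound, a higher number a more soluble compound), the same change gives no change at the digits printed from compound 3 to compound 4 (within the scatter): compound 3 gives 217000 nM and compound 4 gives 217000 nM, which separates these two compounds in neither direction. Nothing shown gives a reason for the large step. From the compounds shown here alone, whether the low number of compound 3 goes with the imidazole end or with the open chain stays open. A plain propylamino chain, or a longer chain ending in the same imidazole, would bear on that.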